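Oxidising a Ring Sulfur: Expected Effect on Solubility

The source may report more compounds than this note shows. Statements on the series, on what has been measured and on what is new or still open speak of the compounds shown alone.

In a physicochemical assay for solubility, read by HPLC, at pH 6.8 (on this read-out lower numbers stand for lower solubility and higher numbers for higher solubility), compound 2 `CC(C)(C)c1cc(NC(=O)[C@@H]2CCCCN2C(=O)N2CCSCC2)no1` gives 46 ug/mL, while compound 1 `CC(C)CN1CCCC[C@H]1C(=O)Nc1cc(C(C)(C)C)on1` gives 32 ug/mL; these two numbers are separated only by a 1.4-fold higher number from compound 1 to compound 2 (0.16 log units; within the scatter), so neither stands apart from the other. Compound 3 `CC(C)(C)c1cc(NC(=O)[C@@H]2CCCCN2C(=O)N2CC[S+]([O-])CC2)no1` differs from compound 2 by a group of 7 heavy atoms (4 carbon, 1 nitrogen, 1 oxygen, 1 sulfur; one six-membered non-aromatic ring with 2 hetero atoms) in place of a group of 6 heavy atoms (4 carbon, 1 nitrogen, 1 sulfur; one six-membered non-aromatic ring with 2 hetero atoms), on a carbonyl carbon. Going by the values given here, no measured step bears on this kind of change, and the single recorded step stayed within the scatter, so the expectation rests on compound 2 alone. Compound 3 is therefore estimated at 80 ug/mL, within a range of 35 ug/mL to 200 ug/mL, which would mean an expected 1.7-fold higher number from compound 2 to compound 3 (0.24 log units; within the scatter).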

Compound 3, solubility: 68 ug/mL
Estimate against measurement, compound 3: 1.2-fold (0.07 log units) above; the measured number falls inside the stated range.
By their numbers in this assay, from the lowest: compounds 1, 2 and 3 (each within the scatter of the next, the first and the last beyond it).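

Placing an oxygen on the ring sulfur, at this carbonyl carbon, gives in this assay a 1.5-fold higher number from compound 2 to compound 3 (0.17 log units; within the scatter) and so cannot be told apart from no change. Going by these compounds alone, the step of a 2.1-fold higher number from compound 1 to compound 3 (0.33 log units; beyond the scatter) is the first here to pass the scatter, though it is modest and swaps the isobutyl group on an amine nitrogen in a ring for the whole oxidised carbonyl group. Nothing available explains either step.

Still open, on these data alone, is how a sulfone, with a second oxygen on that sulfur, would read. As far as these compounds go, a morpholin-4-yl group at the same carbonyl carbon is equally open.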